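Swapping a Thiophenylpyridine for a Small Aminophenyl Group

This account rests on a few compounds, and the source may have more. Where it says the series, first, only, none or still open, it means among the compounds named here.

- Compound 1 `NC1CCC(Nc2nc(NCc3ccc(-c4cccs4)nc3)c3ncn(C4CCCC4)c3n2)CC1` gives 100 nM
- Compound 2 `NC1CCC(Nc2nc(NCc3ccc(-c4ccsc4)nc3)c3ncn(C4CCCC4)c3n2)CC1` gives 150 nM

In a functional assay on K562 cells (Homo sapiens) for inhibition, with a stated time of 72 h (a lower number here means a stronger inhibitor, a higher number a weaker inhibitor), compound 2 sits within the scatter of compound 1, so neither ranks ahead. Compound 3 `Nc1ccccc1CNc1nc(NC2CCC(N)CC2)nc2c1ncn2C1CCCC1` differs from compound 2 by 2-aminophenyl in place of 6-(thiophen-3-yl)pyridin-3-yl on a saturated chain carbon bound to a nitrogen on an aromatic ring at that one place. Among the compounds with values here, the only measured step is a 1.5-fold higher number from compound 1 to compound 2 (0.18 log units; within the scatter) and it concerns the thiophene alone, so it sets no size for this far bigger replacement. A move toward weaker inhibition is expected, though nothing measured fixes its size. The estimated change is a 3.3-fold higher number from compound 2 to compound 3 (0.52 log units; beyond the scatter) with wide uncertainty. Compound 3 is expected near 500 nM with an estimated range from 120 nM to 2000 nM as its likely span.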

Compound 3, half-maximal inhibitory concentration: 4040 nM
Beside the measured number, compound 3's estimate is 8.1-fold (0.91 log units) below it; measured number above the stated range.
By their numbers in this assay, from the lowest: compounds 1 and 2 (each within the scatter of the next); then compound 3.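

In this assay, this position proves far more sensitive than the thiophene swap suggested: 2-aminophenyl replacing 6-(thiophen-3-yl)pyridin-3-yl gives a 27-fold higher number from compound 2 to compound 3 (1.43 log units; beyond the scatter), and replacing 6-(thiophen-2-yl)pyridin-3-yl gives a 40-fold higher number from compound 1 to compound 3 (1.61 log units; beyond the scatter). Here, the saturated chain carbon bound to a nitrogen on an aromatic ring clearly does not treat these aromatic groups alike. Nothing available explains the loss. Still open, on these data alone, is whether the larger number follows from losing the thiophene or from gaining the amine. A plain phenyl ring or an unsubstituted pyridin-3-yl group at this place could separate the two.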